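Changing the aryl on the sulfonyl: compound 4

The compounds below may be only part of what the source reports. "The series", "measured", "known", "first", "only" and "open" are said of these compounds alone.

Of the compounds shown here, three sharing one core have been measured in an assay on isolated protein for displacement of a labelled ligand from metabotropic glutamate receptor 5 (Homo sapiens), with a stated time of 60 min, tested at 1 uM; on this read-out lower numbers stand for less inhibition and higher numbers for more inhibition at the one concentration tested (going by the name of the read-out). Compound 1 `Cc1cc(C)cc(S(=O)(=O)c2cnc3ccc(C)cc3c2N2CCC(C)CC2)c1` gives 80%. Compound 2 `Cc1cc(C)cc(S(=O)(=O)c2cnc3ccc(F)cc3c2N2CCC(C)CC2)c1` gives 83%, and compound 3 `COc1ccc2ncc(S(=O)(=O)c3cc(C)cc(C)c3)c(N3CCC(C)CC3)c2c1` gives 79%. Compound 2 holds the highest of the three numbers shown, but the step of a number 3 percentage points higher from compound 1 to compound 2 (within the scatter) and the step of a number 4 percentage points lower from compound 2 to compound 3 (within the scatter) both lie within the scatter, as does a number 1 percentage points lower from compound 1 to compound 3 (within the scatter). On these numbers the three compounds cannot be told apart, and what differs among them is only the group on an aromatic carbon of the core, where methyl, fluoro and methoxy have all been tried.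

Compound 4 `Cc1ccc(S(=O)(=O)c2cnc3ccc(F)cc3c2N2CCC(C)CC2)cc1F` differs from compound 2 at a different place: 3-fluoro-4-methylphenyl in place of 3,5-dimethylphenyl on a sulfonyl sulfur. For the measured compounds named here, no measured step touches the group on the sulfonyl sulfur, so none of the three steps bears directly on this change; they show only that the measured part of the series has sat at a similar level under three different groups on the core. The expectation for compound 4 therefore rests on the level of compound 2 alone, with a widened range to reflect that the change is of an untested kind. Compound 4 is expected to give about 74%, with a range from 45% to 92%. The estimated step is a number 9 percentage points lower from compound 2 to compound 4 (within the scatter).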

Compound 4, a percentage reported as inhibition, at one concentration (the size of the read-out at that concentration, not a potency): 86%
Compound 4: the middle estimate sits 12 percentage points below what was measured; the range from low to high includes it.
By their numbers in this assay, from the lowest: compounds 3, 1, 2 and 4 (each within the scatter of the next).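

This is the only step shown that touches the group on the sulfonyl sulfur: in this assay, 3-fluoro-4-methylphenyl in place of 3,5-dimethylphenyl gives a number 3 percentage points higher from compound 2 to compound 4 (within the scatter). The earlier compounds shown here showed only that the read-out stayed level under three groups on the core, whereas this pair shows that it also stays level when the aryl on the sulfonyl sulfur is exchanged, at least for these two groups of equal heavy-atom count, neither with hydrogen-bond donors or acceptors. No measurement shown accounts for this lack of a readable difference.

The compounds shown leave open whether that level would hold if the aryl on the sulfonyl sulfur carried an amine or a carboxylic acid, or gave way to a longer chain. They also leave open whether the same exchange would read alike with methyl or methoxy in place of fluoro on the core, and, as every number comes from one concentration, whether compounds that cannot be told apart here would differ in potency.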